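Swapping Cyclohexyl for Benzyl on the Shared Core

The source may hold more compounds than are shown below. What is called first, only, known or untested is meant among the compounds shown, and "the series" means these compounds.

In a functional assay on MCF7 cells (Homo sapiens) for inhibition, read by sulforhodamine B assay, with a stated time of 48 h, tested at 10 uM (a higher number here means more inhibition at the concentration tested (going by the name of the read-out), a lower number less inhibition), compound 2 `c1ccc2c(-c3cn4ccnc4c(-c4ccc5ncn(C6CCCCC6)c5c4)n3)cccc2c1` gives 13%. Compound 1 `COc1ccc(-c2cn3ccnc3c(-c3ccc4ncn(C5CCCCC5)c4c3)n2)cc1` gives 80.2%, and compound 3 `COc1ccccc1-c1cn2ccnc2c(-c2ccc3ncn(C4CCCCC4)c3c2)n1` gives 8.4%; the step of a number 67.2 percentage points lower from compound 1 to compound 2 (beyond the scatter) is large, whereas the step of a number 4.6 percentage points lower from compound 2 to compound 3 (within the scatter) lies within the scatter, so compound 2 sits far below compound 1 and close to compound 3. Compound 4 `c1ccc(Cn2cnc3ccc(-c4nc(-c5cccc6ccccc56)cn5ccnc45)cc32)cc1` differs from compound 2 by benzyl in place of cyclohexyl on an aromatic nitrogen. Going by the values given here, none of the measured steps touches this ring nitrogen; all three alter the aromatic group on the carbon, where a number 71.8 percentage points lower from compound 1 to compound 3 (beyond the scatter) is also large. The expected step is therefore none beyond the scatter, and compound 4 is estimated at 13%, between 0% and 40%, a step of no change at the digits printed from compound 2 to compound 4 (within the scatter).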

Compound 4, a percentage reported as inhibition, at one concentration (the size of the read-out at that concentration, not a potency): 29.2%
Compound 4: the middle estimate sits 16.2 percentage points below what was measured; the range from low to high includes it.
By their numbers in this assay, from the lowest: compounds 3 and 2 (each within the scatter of the next); then compound 4; then compound 1.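

In this assay, benzyl in place of cyclohexyl on the aromatic nitrogen gives a number 16.2 percentage points higher from compound 2 to compound 4 (beyond the scatter), so the group on this ring nitrogen can also move the number, not only the aromatic group on the carbon. This step is modest beside the large steps seen on the carbon. Nothing measured here bears on what lies behind it.

The compounds shown leave open whether benzyl would give a similar step with 4-methoxyphenyl on the carbon. They also leave open how a longer chain or an amine-bearing chain on this nitrogen would read.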